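This account rests on a few compounds, and the source may have more. Where it says the series, first, only, none or still open, it means among the compounds named here.

Working notes on the series. In a functional assay on PC-3 cells (Homo sapiens) for antiproliferative activity, read by CCK-8 assay, with a stated time of 6 days (a higher number here means a weaker inhibitor, a lower number a stronger inhibitor), compound 1 `Cc1noc(C)c1-c1cccc(Oc2ccc(C#N)c(C(F)(F)F)c2)c1` has the entry "not determined" (no result reported), so it offers no reference point. Compound 2 `CCN(c1cccc(-n2ccnc2)c1)c1ccc(C#N)c(C(F)(F)F)c1` gives > 30000 nM, which is a limit of the assay and not a number. Compound 3 `CCN(c1ccc(C#N)c(Cl)c1)c1cc(-c2ccc(F)nc2)ccc1C` gives > 30000 nM, which is also a limit and not a number. Going by the values given here, the series so far therefore comes down to the limit of > 30000 nM in this assay, at which 2 of the 3 values shown sit, and compound 3 stands at that limit with no measured potency.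

Compound 4 `CCN(c1ccc(C#N)c(Cl)c1)c1cc(-c2cccnc2)ccc1C` differs from compound 3 in one place: hydrogen in place of fluoro on an aromatic carbon. Hydrogen takes the place of fluoro on an aromatic carbon next to the ring nitrogen, so that 6-fluoropyridin-3-yl becomes pyridin-3-yl. Among the compounds with values here, no measured pair shows what this change does.

The expected step of a number no higher from compound 3 to compound 4 (the limit leaves the size open) in this assay is none beyond the scatter, with neither direction favoured. This expectation rests on compound 3 at its limit of > 30000 nM. The estimate for compound 4 is 30000 nM, with an expected range of 10000 nM to 60000 nM.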

Compound 4, half-maximal inhibitory concentration: 11000 nM
Beside the measured number, compound 4's estimate is 2.7-fold (0.44 log units) above it, within the range that was stated.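

In this assay, hydrogen in place of fluoro on the aromatic carbon next to the ring nitrogen gives an at least 2.7-fold lower number from compound 3 to compound 4 (0.43 log units; beyond the scatter), the first measured read on this position and this change. Going by these compounds alone, compound 4 is also the first compound with a number and not a limit, so 6-fluoropyridin-3-yl to pyridin-3-yl is a change that this position registers, in a single pair. The step has a floor but no known size because compound 3 stands at a limit: the limit of > 30000 nM in this assay, at which 2 of the 4 values shown sit.

As far as these compounds go, how other groups at this carbon, such as an amine or a methoxy, would compare with hydrogen and fluoro stays open. From the compounds shown here alone, whether the same change would carry over to a core with trifluoromethyl in place of chloro also stays open.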